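Replacing a Small Ring by an Ether Chain

A few compounds are considered here, and "the series" means these few. Any claim that something is new, unique, unknown or untested is made for them only; others in the source may bear on it.

Three analogues built on one shared core differ only in the group on a saturated chain carbon bound to an aromatic nitrogen. In a functional assay on MCF7 cells (Homo sapiens) for antiproliferative activity (a higher number here means a weaker inhibitor, a lower number a stronger inhibitor), compound 1 `C#CCCCn1c(Cc2cc(OC)c(OC)c(OC)c2)nc2c(N)ncnc21` gives 24000 nM, compound 2 `CC/C=C/Cn1c(Cc2cc(OC)c(OC)c(OC)c2)nc2c(N)ncnc21` gives 46800 nM, and compound 3 `COc1cc(Cc2nc3c(N)ncnc3n2CC2(C)CC2)cc(OC)c1OC` gives 112000 nM. Compound 3 therefore carries the highest number of the three: the step of a 4.7-fold higher number from compound 1 to compound 3 (0.67 log units; beyond the scatter) is modest but beyond the scatter, and a 2.4-fold higher number from compound 2 to compound 3 (0.38 log units; beyond the scatter) is likewise beyond it, whereas a 2.0-fold higher number from compound 1 to compound 2 (0.29 log units; within the scatter) stays within the scatter.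

Compound 4 `COc1cc(Cc2nc3c(N)ncnc3n2CCOC(C)C)cc(OC)c1OC` is the untested neighbour of compound 3, with isopropoxymethyl in place of 1-methylcyclopropyl on a saturated chain carbon bound to an aromatic nitrogen. The two measured steps that end at compound 3 both run the same way: moving from an open chain, whether but-3-yn-1-yl or but-1-en-1-yl, to the 1-methylcyclopropyl raised the number modestly. Because the step of a 4.7-fold higher number from compound 1 to compound 3 (0.67 log units; beyond the scatter) went with the change from an open chain to the ring, and compound 4 again carries an open chain, though of a different kind from either, a modest drop of about that size is expected, so that the step of a 2.5-fold lower number from compound 3 to compound 4 (0.40 log units; beyond the scatter) is anticipated. Compound 4 is accordingly estimated at 45000 nM in this assay, with a range from 18000 nM to 115000 nM.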

Compound 4, half-maximal inhibitory concentration: 38900 nM
Estimate against measurement, compound 4: 1.2-fold (0.06 log units) above; measured number inside the range.
By their numbers in this assay, from the lowest: compounds 1, 4 and 2 (each within the scatter of the next); then compound 3.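

In this assay, within the data shown here, the step of a 2.9-fold lower number from compound 3 to compound 4 (0.46 log units; beyond the scatter) is modest but beyond the scatter, so compound 3, the only one with a ring, now stands apart from three open-chain analogues rather than two. Compound 4 falls in with the other open chains, as a 1.2-fold lower number from compound 2 to compound 4 (0.08 log units; within the scatter) and a 1.6-fold higher number from compound 1 to compound 4 (0.21 log units; within the scatter) both stay within the scatter, and so the hydrogen-bond acceptor in isopropoxymethyl shows no separate effect on the number here. Nothing available explains why the ring-bearing compound 3 stands apart from the open chains.

The compounds shown leave open whether an amine, a hydroxyl or a longer chain in place of isopropoxymethyl would stay with the open chains. They also leave open whether plain cyclopropyl, without the methyl, would share the number of compound 3.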